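Isopropylamino analogue within the pyridinylamino furopyridine series

The source may hold more compounds than are shown below. What is called first, only, known or untested is meant among the compounds shown, and "the series" means these compounds.

Compound 1 `CCCCNc1oc2c(C)ncc(CO)c2c1Nc1ccccn1` carries a butylamino group on the shared core and gives 9380 nM in a functional assay on HEK293 cells for agonist activity at Toll-like receptor 8 (Homo sapiens), read by reporter gene assay; a lower number here means that less compound is needed, a higher number that more compound is needed for the effect. Compound 2 `CCOC(=O)CNc1oc2c(C)ncc(CO)c2c1Nc1ccccn1` replaces the butyl chain with an (ethoxycarbonyl)methyl group; in this assay compound 2 is reported as "not active" (no number reported), with no number, so it cannot be placed on a scale beside compound 1. Compound 3 `Cc1ncc(CO)c2c(Nc3ccccn3)c(NC(C)C)oc12` differs from compound 2 by isopropyl in place of (ethoxycarbonyl)methyl on a nitrogen on an aromatic ring. The change returns to a plain alkyl substituent on that nitrogen, as in compound 1, so a measurable number is expected again rather than an inactive report. Compound 3 is estimated at 15000 nM, with a range from 4000 nM to 60000 nM.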

Compound 3, half-maximal effective concentration: "not active" (no number reported)
No number was reported for compound 3; the estimate stays without a comparison.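

Compound 2 and compound 3 are both reported as not active, without a number, so no step can be read between them. The compounds shown leave open how far activity depends on the amino substituent. No other data bear on this result.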